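Amine substituent series: from compound 3 to compound 4

This account rests on a few compounds, and the source may have more. Where it says the series, first, only, none or still open, it means among the compounds named here.

Compounds measured in a functional assay on CCRF-CEM cells (Homo sapiens); on this read-out lower numbers stand for higher toxicity in this test and higher numbers for lower toxicity in this test:
compound 1, `Cc1cn([C@@H]2O[C@H](CO[Si](C)(C)C(C)(C)C)[C@@]3(OS(=O)(=O)C=C3NCCC(=O)OCc3ccccc3)[C@H]2O[Si](C)(C)C(C)(C)C)c(=O)n(C)c1=O`: > 250000 nM, a limit of the test
compound 2, `Cc1cn([C@@H]2O[C@H](CO[Si](C)(C)C(C)(C)C)[C@@]3(OS(=O)(=O)C=C3NC(=O)c3ccccc3)[C@H]2O[Si](C)(C)C(C)(C)C)c(=O)n(C)c1=O`: 4910 nM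
compound 3, `COC(=O)CCNC1=CS(=O)(=O)O[C@@]12[C@@H](CO[Si](C)(C)C(C)(C)C)O[C@@H](n1cc(C)c(=O)n(C)c1=O)[C@@H]2O[Si](C)(C)C(C)(C)C`: > 250000 nM, a limit of the test

Compound 3 stands at the limit, and its value is not a number. The same holds for compound 1, so that two of the three values sit at the limit of > 250000 nM in this assay, at which 2 of the 3 values shown sit. Only compound 2 gives a number in this assay, and both steps that lead to it are large: an at least 50-fold lower number from compound 1 to compound 2 (1.70 log units; beyond the scatter), and in the other direction an at least 50-fold higher number from compound 2 to compound 3 (1.70 log units; beyond the scatter). The step that the two limits leave unreadable from compound 1 to compound 3 links two limits and gives no size.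

Compound 4, `CC(=O)NC1=CS(=O)(=O)O[C@@]12[C@@H](CO[Si](C)(C)C(C)(C)C)O[C@@H](n1cc(C)c(=O)n(C)c1=O)[C@@H]2O[Si](C)(C)C(C)(C)C`, differs from compound 3 as acetyl in place of 2-(methoxycarbonyl)ethyl on an amine nitrogen. For the measured compounds named here, the steps that bear on this are the two in which benzoyl enters or leaves the amine nitrogen, each at least large, with the benzoyl compound on the measurable side. Acetyl, like benzoyl, carries a carbonyl on the amine nitrogen, so a large step downward is expected, though acetyl is the smaller group and the full size of the benzoyl step need not be reached. The estimate for compound 4 in this assay is therefore 20000 nM, within 4000 nM to 150000 nM, an expected step of an at least 12-fold lower number from compound 3 to compound 4 (1.09 log units; beyond the scatter).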

Compound 4, half-maximal cytotoxic concentration: 25700 nM
The estimate for compound 4 lay 1.3-fold (0.11 log units) below the measured number; the range from low to high includes it.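

In this assay, acetyl in place of 2-(methoxycarbonyl)ethyl on the amine nitrogen gives an at least 9.7-fold lower number from compound 3 to compound 4 (0.98 log units; beyond the scatter), and acetyl in place of 2-(benzyloxycarbonyl)ethyl gives an at least 9.7-fold lower number from compound 1 to compound 4 (0.98 log units; beyond the scatter); compound 2 and compound 4 now both carry a carbonyl on this nitrogen and both give numbers, and no compound shown goes against this. For the compounds shown here, the group on that carbonyl carbon also counts, since methyl in place of phenyl gives a 5.2-fold higher number from compound 2 to compound 4 (0.72 log units; beyond the scatter), a step that the earlier compounds, with only one number among them, could not show. Compound 1 and compound 3 stand at a limit of the test and not at a number, so the two steps that start from them give only a bound: the limit of > 250000 nM in this assay, at which 2 of the 4 values shown sit.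

The compounds shown leave open where a free amine on the same carbon would stand, and whether the number keeps moving with the group on the carbonyl carbon when that group is a longer chain such as propyl or a substituted phenyl. They also leave open whether the step from acetyl to benzoyl holds on a core with free hydroxyl groups in place of the silyl ethers.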